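A few compounds are considered here, and "the series" means these few. Any claim that something is new, unique, unknown or untested is made for them only; others in the source may bear on it.

Compound 1 `Cc1ccc(NC(=O)c2cccc(C(F)(F)F)c2)cc1OCCNC(=O)c1cccnc1`: > 10000 nM
Compound 2 `Cc1ccc(NC(=O)c2cccc(C(F)(F)F)c2)cc1OC1CCN(C(=O)c2ccncc2)CC1`: > 10000 nM

The measure here is an ADME assay on BaF3 cells (Mus musculus) for antiproliferative activity; a higher number here means a weaker inhibitor of growth, a lower number a stronger inhibitor of growth. In this test, compound 1 reads > 10000 nM, which is a limit of the assay and not a number. Compound 2 reads > 10000 nM, which is likewise a limit. The whole record so far is therefore (the limit of > 10000 nM in this assay, at which 2 of the 2 values shown sit), so compound 2 has no exact value to serve as a starting point.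

Compound 3 `C=CC(=O)N1CCC(Oc2cc(NC(=O)c3cccc(C(F)(F)F)c3)ccc2C)CC1` keeps the shared core of compound 2 and differs in one place: vinyl in place of pyridin-4-yl on a carbonyl carbon.

For the measured compounds named here, no measured pair shows what a change of this kind does in this assay, so any forecast is uncertain. A modest shift towards stronger growth inhibition is expected, although compound 3 could well stay at the same limit. The expected change is an at least 1.6-fold lower number from compound 2 to compound 3 (0.22 log units; that floor lies within the scatter), and this is only an estimate. For compound 3 the estimated value is 6000 nM, with an expected range of 1500 nM to 10000 nM.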

Compound 3, concentration for 50% growth inhibition: > 10000 nM
Compound 3: a limit, no number; the forecaster's own chance of this, stated with the estimate: 55%; middle value at least 1.6-fold (0.22 log units) from the limit.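

The change from compound 2 to compound 3, vinyl in place of pyridin-4-yl, cannot be read as a step, since both compounds give a limit and not a number in this assay. All three compounds now sit at the same point: the limit of > 10000 nM in this assay, at which 3 of the 3 values shown sit. The compounds shown leave open what this change does to growth inhibition, and how strongly any of the three inhibits growth.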